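Amide to Urea on a Shared Pyrazole Scaffold

The source may report more compounds than this note shows. Statements on the series, on what has been measured and on what is new or still open speak of the compounds shown alone.

Measured so far in a functional assay on SR cells (Homo sapiens) for inhibition, read by sulforhodamine B assay, with a stated time of 48 h; on this read-out lower numbers stand for stronger inhibition of growth and higher numbers for weaker inhibition of growth:
compound 1 `O=C(Nc1cccc(-n2cc(-c3ccncc3)c(-c3ccc(Cl)c(O)c3)n2)c1)Nc1cccc(C(F)(F)F)c1` gives 20000 nM
compound 2 `COc1cc(-c2nn(-c3cccc(NC(=O)Nc4cc(C(F)(F)F)cc(C(F)(F)F)c4)c3)cc2-c2ccncc2)ccc1Cl` gives 3970 nM
compound 3 `COc1cc(-c2nn(-c3cccc(NC(=O)c4cccc(C(F)(F)F)c4)c3)cc2-c2ccncc2)ccc1Cl` gives 4590 nM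

Among these three, compound 3 holds the second highest number. Compound 2 lies nearest to it, and the two values fall within the usual scatter, so no order between compound 2 and compound 3 can be read from them. Compound 1 lies furthest from compound 3, with a clearly higher number that is beyond the scatter, so compound 1 inhibits growth more weakly than compound 3.

Compound 4 `COc1cc(-c2nn(-c3cccc(NC(=O)Nc4cccc(C(F)(F)F)c4)c3)cc2-c2ccncc2)ccc1Cl` is not yet measured. It differs from compound 3 in one place: (3-(trifluoromethyl)phenyl)amino in place of 3-(trifluoromethyl)phenyl on a carbonyl carbon. In plain words, the carbonyl that links the two aryl groups in compound 3 carries one amide-type nitrogen; in compound 4 it carries a second one, turning an amide into a urea while the rest of the molecule is kept.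

For the measured compounds named here, no measured pair here isolates exactly this change. Compound 2 is a urea that differs from compound 4 only in a second trifluoromethyl group, and compound 2 and compound 3 sit within the scatter of each other. On that basis the step of a 1.0-fold lower number from compound 3 to compound 4 (0.01 log units; within the scatter) is expected to be small, with no direction beyond the scatter, and compound 4 is expected to give about 4500 nM in this assay, somewhere between 1500 nM and 13000 nM.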

Compound 4, concentration for total growth inhibition: 2840 nM
Compound 4: the middle estimate sits 1.6-fold (0.20 log units) above what was measured; low and high end bracket the measured number.
By their numbers in this assay, from the lowest: compounds 4, 2 and 3 (each within the scatter of the next); then compound 1.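

In this assay the direct pair for this change can now be read: turning the amide into a urea at this carbonyl carbon gives a 1.6-fold lower number from compound 3 to compound 4 (0.21 log units; within the scatter) and so, despite the added amino nitrogen and its hydrogen-bond donor, shows no clear gain or loss in growth inhibition. Taking away the second trifluoromethyl group from the urea gives a 1.4-fold lower number from compound 2 to compound 4 (0.15 log units; within the scatter) and so also leaves no readable difference, which means that compounds 2, 3 and 4 cannot be put in order. Among the single changes now available, only the one at the oxygen on the aromatic ring goes beyond the scatter: methyl in place of hydrogen there gives a 7.0-fold lower number from compound 1 to compound 4 (0.85 log units; beyond the scatter) and is a modest step, while neither change at the linker or on the trifluoromethyl-bearing ring can be told apart from noise.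

Going by these compounds, it remains open whether an ethyl group on that oxygen, or an amine or a carboxylic acid in place of the trifluoromethyl group, would shift the number beyond the scatter. Nothing on hand explains why any of these steps has the size it has.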